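Imidazole for thiazole among three assay limits

A few compounds are considered here, and "the series" means these few. Any claim that something is new, unique, unknown or untested is made for them only; others in the source may bear on it.

The measured compounds:
- compound 1 `COC(=O)c1cc(=O)c2c(OC)cc(OC)cc2n1C`: in a functional assay on SEM cells (Homo sapiens) for antiproliferative activity, with a stated time of 72 h (on this read-out lower numbers stand for an effect already at smaller amounts and higher numbers for an effect only at larger amounts of compound), compound 1 gives > 19000 nM
- compound 2 `COc1cc(OC)c2c(=O)cc(C(=O)Nc3cccc(N4CCCC4)c3)[nH]c2c1`: in this assay compound 2 gives > 58600 nM
- compound 3 `COc1cc(OC)c2c(=O)cc(C(=O)Nc3cccc(-c4nccs4)c3)[nH]c2c1`: in this assay compound 3 gives > 54000 nM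

Each of these three values is a limit of this assay and not a number. The value of compound 1 is such a limit (the limit of > 19000 nM in this assay, at which 1 of the 3 values shown sits). The value of compound 2 is such a limit (the limit of > 58600 nM in this assay, at which 1 of the 3 values shown sits). The value of compound 3 is such a limit (the limit of > 54000 nM in this assay, at which 1 of the 3 values shown sits). Compound 3 therefore stands nowhere in particular: it shares the position of the other two, all at the edge of what the assay can report.

Within the data shown here, the one measured step, from compound 2 to compound 3, is a step that the two limits leave unreadable from compound 2 to compound 3, so its size and direction are unknown.

Compound 4 `COc1cc(OC)c2c(=O)cc(C(=O)Nc3cccc(-n4ccnc4)c3)[nH]c2c1` differs from compound 3 by 1H-imidazol-1-yl in place of 1,3-thiazol-2-yl on an aromatic carbon. Among the measured compounds shown here, no measured step bears on this change, and the three values give no direction to expect. Since compound 3 sits at a limit (the limit of > 54000 nM in this assay, at which 1 of the 3 values shown sits), compound 4 is expected to sit at a limit as well, with an expected step that the limit leaves unreadable from compound 3 to compound 4 in this assay. The estimate for compound 4 is 60000 nM, within 20000 nM to 200000 nM.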

Compound 4, half-maximal effective concentration: > 16300 nM
Compound 4 was reported as a limit; the forecaster's own chance of this, stated with the estimate: 85%; the middle value does not contradict the limit.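

In this assay compound 4 gives > 16300 nM, which is a limit of the assay and not a number. Among these compounds, compound 2, compound 3 and compound 4 are all reported as limits, so no step among them can be read. The compounds shown leave open whether the 1H-imidazol-1-yl, 1,3-thiazol-2-yl or pyrrolidin-1-yl group changes antiproliferative activity at all.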